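This account rests on a few compounds, and the source may have more. Where it says the series, first, only, none or still open, it means among the compounds named here.

Compound 1 `O=C(Nc1cc(-c2ccccc2)nn1-c1ccccc1)c1ccc(C(F)(F)F)cc1` and compound 2 `O=C(Nc1cc(-c2ccccc2)nn1-c1ccccc1Br)c1cccc([N+](=O)[O-])c1` share a core, and each carries an aromatic group on the carbonyl carbon of the amide. In a functional assay on cells for positive allosteric modulation of metabotropic glutamate receptor 5 (Rattus norvegicus), read by calcium flux (a lower number here means that less compound is needed, a higher number that more compound is needed for the effect), compound 1 gives 38 nM, and compound 2 gives 68 nM. Compound 1 thus has the lowest of the two numbers, yet its gap to compound 2 lies within the scatter of repeated measurements, so the two cannot be ranked against each other. Within the data shown here, no pair among the measured compounds differs in only one place, so no single step has yet been measured in this assay.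

Compound 3 `O=C(CC1CCCC1)Nc1cc(-c2ccccc2)nn1-c1ccccc1` differs from compound 1 in one place: cyclopentylmethyl in place of 4-(trifluoromethyl)phenyl on a carbonyl carbon. Among the measured compounds shown here, compound 3 is the first of the three in which a five-membered non-aromatic ring takes this place on the carbonyl carbon. For the measured compounds named here, with no measured step of this kind, the expectation for compound 3 rests on the two values shown and on the size of the change alone. The step is estimated to raise the number, by a 6.6-fold higher number from compound 1 to compound 3 (0.82 log units; beyond the scatter), beyond the scatter. Compound 3 is therefore expected to give 250 nM in this assay, with a range from 60 nM to 2000 nM.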

Compound 3, half-maximal effective concentration: 350 nM
Estimate against measurement, compound 3: 1.4-fold (0.15 log units) below; low and high end bracket the measured number.
By their numbers in this assay, from the lowest: compounds 1 and 2 (each within the scatter of the next); then compound 3.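

In this assay, the place on the carbonyl carbon now has its first single-change measurement: putting cyclopentylmethyl in place of 4-(trifluoromethyl)phenyl gives a 9.2-fold higher number from compound 1 to compound 3 (0.96 log units; beyond the scatter) with the rest of the structure held constant. The group at this place therefore matters to the number, and an aromatic group here is not interchangeable with this non-aromatic ring on a one-carbon link. Yet the step changes the ring type, the heavy-atom count and the presence of fluorine all at once, while neither group has a hydrogen-bond donor or acceptor, and no measurement bears on why the number rises.

From the compounds shown here alone, it remains open whether the aromatic ring or the trifluoromethyl group accounts for the step, a question that a plain phenyl or a cyclohexyl group at this place would help to settle. Also open, going by these compounds, is how this assay would respond to an amine or a carboxylic acid on the group at this place, or to a longer chain in place of cyclopentylmethyl.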